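The compounds below may be only part of what the source reports. "The series", "measured", "known", "first", "only" and "open" are said of these compounds alone.

Of the compounds shown here, three sharing one core have been measured in a functional assay on BXPC-3 cells (Homo sapiens) for inhibition, read by MTT assay, with a stated time of 7 days; a lower number here means a stronger inhibitor, a higher number a weaker inhibitor. Compound 1 `CCOC(=O)[C@@H]1CCCN(S(=O)(=O)c2ccc(S(=O)(=O)N3CCOCC3)cc2)C1` carries an ethyl ester and a morpholine sulfonamide, and in this assay compound 1 gives 23400 nM. Compound 2 `CCN(CC)S(=O)(=O)c1ccc(S(=O)(=O)N2CCC[C@@H](C(=O)N(C)C(C)C)C2)cc1` has a diethylsulfonamide and an isopropyl(methyl)carbamoyl group, and in this assay compound 2 gives 7700 nM. Compound 3 `CCN(CC)S(=O)(=O)c1ccc(S(=O)(=O)N2CCC[C@@H](C(=O)N3CCC(c4nc(C(C)C)no4)CC3)C2)cc1` bears a far larger amide built on a piperidine that carries an oxadiazole, and in this assay compound 3 gives 300 nM. Compound 2 thus stands second highest of the three numbers: compound 1 sits above it by a gap beyond the usual scatter, and compound 3 sits far below it, also beyond the scatter.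

Compound 4 `CCN(CC)S(=O)(=O)c1ccc(S(=O)(=O)N2CCC[C@@H](C(=O)NC3COC3)C2)cc1` is the not yet measured neighbour of compound 2. The change is (oxetan-3-yl)amino in place of isopropyl(methyl)amino on a carbonyl carbon. One small amide substituent is swapped for another small one; the single case of a strong gain in this set, compound 3, came with a much larger amide, so no such gain is foreseen here. The step is expected to be small, a 1.3-fold higher number from compound 2 to compound 4 (0.11 log units; within the scatter), with no clear direction beyond the scatter. Compound 4 is therefore estimated at 10000 nM, with a likely range between 3000 nM and 40000 nM.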

Compound 4, half-maximal inhibitory concentration: 13800 nM
The estimate for compound 4 lay 1.4-fold (0.14 log units) below the measured number; low and high end bracket the measured number.
By their numbers in this assay, from the lowest: compound 3; then compounds 2, 4 and 1 (each within the scatter of the next, the first and the last beyond it).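

In this assay, among the compounds shown here, putting (oxetan-3-yl)amino in place of isopropyl(methyl)amino on a carbonyl carbon gives a 1.8-fold higher number from compound 2 to compound 4 (0.25 log units; within the scatter), and this is the first comparison in the set where only one place differs. The step swaps a ring-free group without hydrogen-bond donors or acceptors for one with a four-membered ring, a hydrogen-bond donor and a hydrogen-bond acceptor, yet the two numbers cannot be told apart, so this position tolerates that particular exchange without a clear loss or gain. No measurement at hand speaks to the reason for this result.

The swap also alters several features at once, so a (methyl)(oxetan-3-yl)amino group, which keeps the ring but lacks the amide hydrogen, would be needed to separate them. For the compounds shown here, also open is how a plain piperidine amide without the oxadiazole, or a carboxylic acid on this carbonyl carbon, would read against compound 3 at 300 nM, the only compound here with a number far below the others.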